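This account rests on a few compounds, and the source may have more. Where it says the series, first, only, none or still open, it means among the compounds named here.

Compound 1 `COc1cc(-c2ccnc3cc(-c4ccc(C)cc4)nn23)cc(OC)c1OC`, 47 nM.
Compound 2 `Cn1ccc2cc(-c3cc4nccc(-c5ccc(F)cc5)n4n3)ccc21`, 4580 nM.
Compound 3 `COc1cc(-c2ccnc3c(-c4ccc(C)cc4)cnn23)cc(OC)c1OC`, > 10000 nM.

In a functional assay on MCF7 cells (Homo sapiens) for inhibition, read by CCK-8 assay, with a stated time of 48 h (a higher number here means a weaker inhibitor, a lower number a stronger inhibitor), compound 1 gives 47 nM, the lowest of the two numbers shown, while compound 2 gives 4580 nM, a gap far beyond the scatter. For compound 3 the assay reports only a limit, > 10000 nM, as a reading of the limit of > 10000 nM in this assay, at which 1 of the 3 values shown sits. Compound 4 `CCOC(=O)c1ccc(-c2cc3nccc(-c4cc(OC)c(OC)c(OC)c4)n3n2)cc1` has not yet been measured; it differs from compound 1 in one place: ethoxycarbonyl in place of methyl on an aromatic carbon. Going by the values given here, no step between measured compounds shows a change of this kind, so the step from compound 1 to compound 4 in this assay is expected to be a modest loss, a 3.2-fold higher number from compound 1 to compound 4 (0.50 log units; beyond the scatter). Compound 4 is therefore estimated at 150 nM, expected to fall between 40 nM and 600 nM.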

Compound 4, half-maximal inhibitory concentration: > 10000 nM
Compound 4: only a limit was reported; the forecaster's own chance of this, stated with the estimate: 5%; middle value at least 66-fold (1.82 log units) away from the limit.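

At the aromatic carbon para to a large group, replacing methyl with ethoxycarbonyl in this assay gives an at least 210-fold higher number from compound 1 to compound 4 (2.32 log units; beyond the scatter). This is the first step among the compounds shown that changes one place only, and it shows that activity at this position depends strongly on the group carried there. Compound 4 stands at a limit rather than a number, so the full size of the loss stays unknown: the limit of > 10000 nM in this assay, at which 2 of the 4 values shown sit.

The compounds shown leave open whether the loss follows from the ester itself or from the longer group. A carboxylic acid or an ethyl group at this position could separate the two.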